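Swapping 3-fluorobenzyl for 1-phenylethyl on the shared core

The source may report more compounds than this note shows. Statements on the series, on what has been measured and on what is new or still open speak of the compounds shown alone.

Of the compounds shown here, three with one shared core have been measured in a physicochemical assay for solubility, using the shake flask method, in simulated intestinal fluid, measured as kinetic solubility, with a stated time of 2 h, at 25 degrees C, at pH 6.5; on this read-out higher numbers stand for higher solubility and lower numbers for lower solubility. Compound 1 `Cc1noc(-c2nc(C)c3c(c2N)C(=O)N(CC2CCNCC2)C3=O)n1` gives 160000 nM, and compound 2 `Cc1noc(-c2nc(C)c3c(c2N)C(=O)N(CC2CCOCC2)C3=O)n1` gives 5700 nM. Compound 3 `Cc1noc(-c2nc(C)c3c(c2N)C(=O)N(Cc2cccc(F)c2)C3=O)n1` is reported as < 5000 nM, which is a limit of the assay and not a number.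

Two large steps mark the loss of the piperidin-4-yl group: a 28-fold lower number from compound 1 to compound 2 (1.45 log units; beyond the scatter), and an at least 32-fold lower number from compound 1 to compound 3 (1.50 log units; beyond the scatter). The third step, an at least 1.1-fold lower number from compound 2 to compound 3 (0.05 log units; that floor lies within the scatter), sets no order beyond the scatter.

Compound 4 `Cc1noc(-c2nc(C)c3c(c2N)C(=O)N(C(C)c2ccccc2)C3=O)n1` carries 1-phenylethyl in place of 3-fluorobenzyl on an amide-type nitrogen in a ring. For the measured compounds named here, no measured step makes this exchange directly. The closest guide is the step that leads to compound 3, an at least 32-fold lower number from compound 1 to compound 3 (1.50 log units; beyond the scatter), since compound 4 also lacks the piperidin-4-yl group and keeps a six-membered aromatic ring of carbon only. The large steps therefore offer no reason to expect a return toward the value of compound 1, 160000 nM. The estimated step is a step that the limit leaves unreadable from compound 3 to compound 4, and no change beyond the scatter is expected. Compound 4 is expected at about 3500 nM, with an estimated range of 1000 nM to 9000 nM.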

Compound 4, solubility: 10900 nM
The estimate for compound 4 lay 3.1-fold (0.49 log units) below the measured number; the measured number lies above the stated range.
By their numbers in this assay, from the lowest: compounds 2 and 4 (each within the scatter of the next); then compound 1. At a limit, below all of these: compound 3.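

In this assay, replacing 3-fluorobenzyl with 1-phenylethyl on an amide-type nitrogen in a ring gives an at least 2.1-fold higher number from compound 3 to compound 4 (0.33 log units; beyond the scatter), so this position responds to an exchange between two groups that each carry one six-membered aromatic ring of carbon only and have no hydrogen-bond donors or acceptors. Compound 3 is known only through a limit of the assay, so this step sets a floor and not a size: the limit of < 5000 nM in this assay, at which 1 of the 4 values shown sits. The other two steps place 1-phenylethyl among the groups already seen at this position, with a 1.9-fold higher number from compound 2 to compound 4 (0.28 log units; within the scatter) and a 15-fold lower number from compound 1 to compound 4 (1.17 log units; beyond the scatter), so the large gap to the (piperidin-4-yl)methyl compound remains.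

The exchange changes two things at once, removing the fluorine and adding a carbon to the chain, and the compounds shown do not separate these changes, as an unsubstituted benzyl group or a 1-(3-fluorophenyl)ethyl group might. They also leave open whether an amine other than piperidine, such as an open-chain amine, or a carboxylic acid at this position would come close to the value of compound 1, 160000 nM.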